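This account rests on a few compounds, and the source may have more. Where it says the series, first, only, none or still open, it means among the compounds named here.

Going by the values given here, compound 3 `COC(=O)c1sc2cc(C#Cc3ccc(N(C)C)cc3)cnc2c1N` is the only compound with a number in a functional assay on NCI-H460 cells (Homo sapiens) for inhibition, read by sulforhodamine B assay, with a stated time of 48 h (a lower number here means a stronger inhibitor of growth, a higher number a weaker inhibitor of growth), where compound 3 gives 16600 nM. Compound 1 `COC(=O)c1sc2cc(C#Cc3ccccc3F)cnc2c1N` gives in this assay only a limit, > 150000 nM. Compound 2 `COC(=O)c1sc2cc(C#Cc3cccnc3)cnc2c1N` likewise gives in this assay only a limit, > 150000 nM. Among the compounds with values here, the single measured step, a step that the two limits leave unreadable from compound 1 to compound 2, cannot be read, as both of its ends are limits, so it gives no size for any change. Compound 4 `COC(=O)c1sc2cc(C#Cc3ccc(F)cc3)cnc2c1N` differs from compound 3 by fluoro in place of dimethylamino on an aromatic carbon. Compound 1, which also carries a fluoro group and no dimethylamino group, sits at the limit, while compound 3 holds its number. Compound 4 is therefore expected to weaken, with an estimated step of a 6.0-fold higher number from compound 3 to compound 4 (0.78 log units; beyond the scatter). In this assay compound 4 is expected to give about 100000 nM, between 30000 nM and 300000 nM.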

Compound 4, concentration for 50% growth inhibition: 24000 nM
Beside the measured number, compound 4's estimate is 4.2-fold (0.62 log units) above it, outside the stated range (below it).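

In this assay, fluoro in place of dimethylamino on this aromatic carbon, para to a large group, gives a 1.4-fold higher number from compound 3 to compound 4 (0.16 log units; within the scatter), so a measurable number here does not depend on dimethylamino. The 4-fluorophenyl group also separates compound 4 from both compounds at the limit, with an at least 6.2-fold lower number from compound 1 to compound 4 (0.79 log units; beyond the scatter) and an at least 6.2-fold lower number from compound 2 to compound 4 (0.79 log units; beyond the scatter). These two sizes are only minimum sizes because compounds 1 and 2 give limits rather than numbers: the limit of > 150000 nM in this assay, at which 2 of the 4 values shown sit.

The compounds shown leave open whether a methoxy group or a primary amine on this same aromatic carbon would keep the number where compounds 3 and 4 stand. As far as these compounds go, how far compounds 1 and 2 lie past their limit also stays open.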